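Removing the 2-methylphenyl from compound 3

The source may report more compounds than this note shows. Statements on the series, on what has been measured and on what is new or still open speak of the compounds shown alone.

In a functional assay on NCI-N87 cells (Homo sapiens) for antiproliferative activity (a lower number here means a stronger inhibitor, a higher number a weaker inhibitor), compound 1 `NC1CCN(Cc2ccn3ncnc(Nc4ccccc4)c23)CC1` gives 140 nM while compound 3 `Cc1ccccc1Nc1ncnn2ccc(CN3CCC(N)CC3)c12` gives 3300 nM and so holds the higher of the two numbers. Compound 2 `CC(C)Nc1ncnn2ccc(CN3CCC(N)CC3)c12` stands at "not determined" (no result reported) and offers no comparison. Within the data shown here, the one measured step is large: a 24-fold higher number from compound 1 to compound 3 (1.37 log units; beyond the scatter) on adding a methyl. Compound 4 `NC1CCN(Cc2ccn3ncnc(Nc4cccc(Br)c4)c23)CC1` differs from compound 3 as follows: 3-bromophenyl in place of 2-methylphenyl on a nitrogen on an aromatic ring. Among the measured compounds shown here, it carries no 2-methylphenyl, though no measurement yet isolates the 3-bromophenyl. A move back towards compound 1 is therefore expected, of similar size and opposite direction to that measured step. The expected change is a 33-fold lower number from compound 3 to compound 4 (1.52 log units; beyond the scatter) in this assay as a working estimate. For compound 4 the estimated value is 100 nM with an expected range of 20 nM to 500 nM for now.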

Compound 4, half-maximal inhibitory concentration: 50 nM
Estimate against measurement, compound 4: 2.0-fold (0.30 log units) above; measured number inside the range.
By their numbers in this assay, from the lowest: compound 4; then compound 1; then compound 3.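

At this place, on a nitrogen on an aromatic ring, the aryl group can move the number both ways in this assay: 3-bromophenyl in place of 2-methylphenyl gives the widest gap so far (a 66-fold lower number from compound 3 to compound 4 (1.82 log units; beyond the scatter)). Bromo in place of hydrogen gives a modest gain (a 2.8-fold lower number from compound 1 to compound 4 (0.45 log units; beyond the scatter)), so a substituent on this phenyl is not in itself a loss, as compound 3 alone suggested.

Open, as far as these compounds go, is whether the group or its place on the ring counts; 3-methylphenyl or 2-bromophenyl would separate the two. Nothing at hand gives a reason for these steps.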